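Acetoacetyl Amide in Place of an Aromatic Imine

The compounds below may be only part of what the source reports. "The series", "measured", "known", "first", "only" and "open" are said of these compounds alone.

Three compounds have been tested in a functional assay on Ehrlich cells (Mus musculus) for cytotoxicity, read by trypan blue exclusion, with a stated time of 2 h, tested at 10 ug/mL; a higher number here means a stronger effect of the compound at the concentration tested, a lower number a weaker effect:
compound 1, `N#CC1=C(NC(=O)C2CC2)N(c2ccc(S(N)(=O)=O)cc2)C2=C(C(=O)CCC2)C1c1ccc(Cl)cc1Cl`, gives 20%;
compound 2, `COc1cc(C(=O)NC2=C(C#N)C(c3ccc(Cl)cc3Cl)C3=C(CCCC3=O)N2c2ccc(S(N)(=O)=O)cc2)cc(OC)c1OC`, gives 0%;
compound 3, `CN(C)c1ccc(/C=N/C2=C(C#N)C(c3ccc(Cl)cc3Cl)C3=C(CCCC3=O)N2c2ccc(S(N)(=O)=O)cc2)cc1`, gives 10%.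

Compound 3 stands second highest of the three numbers. The step of a number 10 percentage points lower from compound 1 to compound 3 (within the scatter) lies within the scatter, and the values of compound 3 and compound 2 are within the scatter of each other as well.

Compound 4, `CC(=O)CC(=O)NC1=C(C#N)C(c2ccc(Cl)cc2Cl)C2=C(CCCC2=O)N1c1ccc(S(N)(=O)=O)cc1`, differs from compound 3 in one place: a group of 7 heavy atoms (4 carbon, 1 nitrogen, 2 oxygen; no ring) in place of a group of 11 heavy atoms (9 carbon, 2 nitrogen; one six-membered aromatic ring of carbon only), on a double-bonded ring carbon. Among the compounds with values here, two measured steps bear on this. The step of a number 10 percentage points lower from compound 1 to compound 3 (within the scatter) shows that swapping a small acyl amide for the aromatic imine changed little. The step of a number 20 percentage points lower from compound 1 to compound 2 (beyond the scatter) shows that a large aromatic acyl group lowered the number beyond the scatter. The group entering compound 4 is a small acyclic acyl amide, close in size to the cyclopropyl amide of compound 1 rather than to the trimethoxyphenyl amide of compound 2. Compound 4 is therefore expected to sit near compound 1 and compound 3, with an estimated step of a number 5 percentage points higher from compound 3 to compound 4 (within the scatter), not beyond the scatter. The estimate for compound 4 is 15%, within a range of 0% to 35%.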

Compound 4, a percentage reported as activity, at one concentration (the size of the read-out at that concentration, not a potency): 40%
Beside the measured number, compound 4's estimate is 25 percentage points below it; the measured number lies above the stated range.
By their numbers in this assay, from the lowest: compounds 2, 3 and 1 (each within the scatter of the next, the first and the last beyond it); then compound 4.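

In this assay, the ((2-oxopropyl)carbonyl)amino group sets compound 4 apart from the others: a number 30 percentage points higher from compound 3 to compound 4 (beyond the scatter), a number 40 percentage points higher from compound 2 to compound 4 (beyond the scatter) and a number 20 percentage points higher from compound 1 to compound 4 (beyond the scatter). The last step shows that this position responds even to an exchange between two non-aromatic groups on the carbonyl carbon, 2-oxopropyl in place of cyclopropyl. Nothing available explains the rise. As far as these compounds go, it remains open whether the ketone carbonyl of the 2-oxopropyl group matters or the open chain alone is enough. A propyl group on the same carbonyl carbon would help separate the two.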